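From Fluoro to Bromo on the Shared Core

The source may hold more compounds than are shown below. What is called first, only, known or untested is meant among the compounds shown, and "the series" means these compounds.

In a functional assay on A549 cells (Homo sapiens) for antiproliferative activity, read by MTT assay, with a stated time of 48 h (a lower number here means a stronger inhibitor, a higher number a weaker inhibitor), compound 3 (`COc1ccc(-c2nn(-c3ccccc3)cc2-c2nc3cc(F)ccc3[nH]2)cc1`) gives 1980 nM and compound 2 (`Clc1ccc(-c2nn(-c3ccccc3)cc2-c2nc3cc(Br)ccc3[nH]2)cc1`) gives 2170 nM, two values within the scatter of each other. Compound 1 (`Fc1ccc(-c2nn(-c3ccccc3)cc2-c2nc3cc(Br)ccc3[nH]2)cc1`) gives 5830 nM, a higher number than either. Compound 4 (`COc1ccc(-c2nn(-c3ccccc3)cc2-c2nc3cc(Br)ccc3[nH]2)cc1`) departs from compound 3 by one change: bromo in place of fluoro on an aromatic carbon. This swap has not been measured directly at this place. The nearest measured step is a 2.7-fold lower number from compound 1 to compound 2 (0.43 log units; beyond the scatter), with chloro in place of fluoro on an aromatic carbon at a different place in the molecule. That modest step is only a loose guide, since it involves neither the same place nor the same incoming group. No step beyond the scatter is therefore expected in this assay, and any shift is expected to be slight, with a 1.1-fold lower number from compound 3 to compound 4 (0.04 log units; within the scatter) as the expected step. For compound 4 the estimated value is 1800 nM, within an expected range of 700 nM to 4500 nM.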

Compound 4, half-maximal inhibitory concentration: 6370 nM
Beside the measured number, compound 4's estimate is 3.5-fold (0.55 log units) below it; measured number above the stated range.
By their numbers in this assay, from the lowest: compounds 3 and 2 (each within the scatter of the next); then compounds 1 and 4 (each within the scatter of the next).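

In this assay the group on the six-membered aromatic ring of the fused system proves to matter once the methoxy group is held fixed, for bromo in place of fluoro gives a 3.2-fold higher number from compound 3 to compound 4 (0.51 log units; beyond the scatter) and so counts as a real change at this place. With bromo held fixed, the outcome of placing methoxy at the other site depends on the group it replaces: methoxy in place of chloro gives a 2.9-fold higher number from compound 2 to compound 4 (0.47 log units; beyond the scatter) while methoxy in place of fluoro gives a 1.1-fold higher number from compound 1 to compound 4 (0.04 log units; within the scatter) in this series. No measurement offered here accounts for these shifts.

The compounds shown leave open how chloro, an amine or a nitrile would behave at this place with the methoxy group retained. They also leave open whether the bromo and fluoro swap would give a similar step with chloro or fluoro at the other site.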